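The source may hold more compounds than are shown below. What is called first, only, known or untested is meant among the compounds shown, and "the series" means these compounds.

Measured compounds:
Compound 1, `CCCCCCCCCCCCCCCCCCNC(=O)[C@@H](NC(=O)c1cc2ccccc2[nH]1)[C@@H](C)O` — in a functional assay on HepG2 cells (Homo sapiens) for cytotoxicity, read by MTT assay, with a stated time of 48 h (a higher number here means a weaker inhibitor, a lower number a stronger inhibitor), compound 1 gives 89400 nM.
Compound 2, `CCCCCCCCCCCCCCCCCCNC(=O)[C@@H](NS(=O)(=O)c1ccc(C)cc1)[C@@H](C)O` — in this assay compound 2 gives 75800 nM.

Compound 2 holds the lower of the two numbers, but the step of a 1.2-fold lower number from compound 1 to compound 2 (0.07 log units; within the scatter) is within the scatter, so no order between compound 1 and compound 2 can be read from it.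

Compound 3, `CCCCCCCCCCCCCCCCCCNC(=O)[C@@H](NS(=O)(=O)c1cccs1)[C@@H](C)O`, is not yet measured. It differs from compound 2 only in thiophen-2-yl in place of 4-methylphenyl on a sulfonyl sulfur. Going by the values given here, no measured step touches the group on the sulfonyl sulfur; the single step seen, from an indolylcarbonyl amide to a sulfonamide on the amine nitrogen, was a 1.2-fold lower number from compound 1 to compound 2 (0.07 log units; within the scatter) and gives no lever on this change. With nothing in the series pointing either way, the working expectation for compound 3 is a number close to that of compound 2, a step of a 1.1-fold higher number from compound 2 to compound 3 (0.02 log units; within the scatter), not beyond the scatter. Compound 3 is accordingly estimated at 80000 nM, with a range from 35000 nM to 180000 nM.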

Compound 3, half-maximal inhibitory concentration: > 200000 nM
Compound 3: no number, only a limit; the forecaster's own chance of this, stated with the estimate: 20%; middle value at least 2.5-fold (0.39 log units) away from the limit.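

Going by these compounds alone, the group on the sulfonyl sulfur is the first place where a change moves the number in this assay beyond the scatter: thiophen-2-yl in place of 4-methylphenyl gives an at least 2.6-fold higher number from compound 2 to compound 3 (0.42 log units; beyond the scatter). The sulfonamide link alone does not set the number, as (thiophen-2-yl)sulfonyl in place of (1H-indol-2-yl)carbonyl on the amine nitrogen gives an at least 2.2-fold higher number from compound 1 to compound 3 (0.34 log units; beyond the scatter), while the (4-methylphenyl)sulfonyl compound stayed within the scatter of the amide in a 1.2-fold lower number from compound 1 to compound 2 (0.07 log units; within the scatter). Compound 3 carries a limit of the assay and not a number, and the full size of both new steps stays unknown: the limit of > 200000 nM in this assay, at which 1 of the 3 values shown sits.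

On these data alone, the change swaps the ring and removes the methyl at once, so it remains open whether a plain phenyl or a 5-methylthiophen-2-yl on the sulfonyl sulfur would sit with compound 2 or with compound 3. Also open, as far as these compounds go, is whether the same change holds with a shorter chain in place of the long chain shared by all three compounds.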